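Replacing the Nitrophenyl Group in a Weak MCF7 Inhibitor

The compounds below may be only part of what the source reports. "The series", "measured", "known", "first", "only" and "open" are said of these compounds alone.

This account follows three compounds that share one core and differ only in the group carried on a nitrogen on an aromatic ring. Compound 1 `CC(C)c1ccc(-c2nc(SCc3cn(CC(=O)NC(=O)Nc4ccccn4)nn3)nc(Nc3cccc(C(F)(F)F)c3)c2C#N)cc1` is the strongest inhibitor of the three in a functional assay on MCF7 cells (Homo sapiens) for inhibition, read by MTT assay, with a stated time of 72 h (a lower number here means a stronger inhibitor, a higher number a weaker inhibitor), where compound 1 gives 8620 nM. Compound 2 `CC(C)c1ccc(-c2nc(SCc3cn(CC(=O)NC(=O)Nc4ccccn4)nn3)nc(Nc3cccc([N+](=O)[O-])c3)c2C#N)cc1` gives 25900 nM in this assay, the highest number of the three, and compound 3 `COc1ccccc1Nc1nc(SCc2cn(CC(=O)NC(=O)Nc3ccccn3)nn2)nc(-c2ccc(C(C)C)cc2)c1C#N` gives 19300 nM in this assay. The step of a 3.0-fold higher number from compound 1 to compound 2 (0.48 log units; beyond the scatter) and the step of a 2.2-fold higher number from compound 1 to compound 3 (0.35 log units; beyond the scatter) are both modest but beyond the scatter, whereas the step of a 1.3-fold lower number from compound 2 to compound 3 (0.13 log units; within the scatter) stays within it.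

Compound 4 `CC(C)c1ccc(Nc2nc(SCc3cn(CC(=O)NC(=O)Nc4ccccn4)nn3)nc(-c3ccc(C(C)C)cc3)c2C#N)cc1` has not yet been measured. Its difference from compound 2 is 4-isopropylphenyl in place of 3-nitrophenyl on a nitrogen on an aromatic ring. Going by the values given here, no measured pair makes exactly this change, so the bearing steps are indirect: the step of a 3.0-fold higher number from compound 1 to compound 2 (0.48 log units; beyond the scatter) shows that taking away the nitro group, in favour of trifluoromethyl, is linked to a lower number, and the step of a 2.2-fold higher number from compound 1 to compound 3 (0.35 log units; beyond the scatter) shows compound 1 remaining the lowest of the three. Compound 4 carries no nitro group and no hydrogen-bond acceptor on the entering ring, so a modest step down is expected, a 2.6-fold lower number from compound 2 to compound 4 (0.41 log units; beyond the scatter). Compound 4 is therefore estimated at 10000 nM in this assay, with a range from 3000 nM to 35000 nM.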

Compound 4, half-maximal inhibitory concentration: 28600 nM
For compound 4 the middle estimate is 2.9-fold (0.46 log units) below the measured one; low and high end bracket the measured number.
By their numbers in this assay, from the lowest: compound 1; then compounds 3, 2 and 4 (each within the scatter of the next).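

The result removes the link that the first three compounds seemed to suggest between the nitro group and a weaker reading: a 1.1-fold higher number from compound 2 to compound 4 (0.04 log units; within the scatter) in this assay, so a 4-isopropylphenyl group, with no nitro group and no hydrogen-bond acceptors, cannot be told apart from 3-nitrophenyl on this nitrogen. With a 1.5-fold higher number from compound 3 to compound 4 (0.17 log units; within the scatter) as well, the 2-methoxyphenyl, 3-nitrophenyl and 4-isopropylphenyl compounds form a single band, while a 3.3-fold higher number from compound 1 to compound 4 (0.52 log units; beyond the scatter) confirms that the 3-(trifluoromethyl)phenyl group of compound 1 alone stands apart, making compound 1 the strongest of the four. Nothing in the material shown accounts for this separation.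

The compounds shown leave open whether the trifluoromethyl group is specifically what sets compound 1 apart, since each of the other three differs from it in both the group on the phenyl ring and where that group sits. They also leave open how this assay would read with an unsubstituted phenyl ring on this nitrogen, or with a phenyl ring carrying a chlorine atom, an amine or a carboxylic acid.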